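A few compounds are considered here, and "the series" means these few. Any claim that something is new, unique, unknown or untested is made for them only; others in the source may bear on it.

Measured so far:
compound 1, `CCCCCCCCCCO[C@H]1C=C(COC(C)=O)C(=O)[C@@H]2O[C@@](C)(OC)[C@](C)(OC)O[C@@H]12`: 33600 nM in an assay on isolated protein for inhibition of glutathione S-transferase Mu 1 (Homo sapiens), read by spectrophotometry, with a stated time of 3 min; on this read-out lower numbers stand for stronger inhibition and higher numbers for weaker inhibition
compound 2, `CO[C@H]1C=C(COC(C)=O)C(=O)[C@@H]2O[C@@](C)(OC)[C@](C)(OC)O[C@@H]12`: "not determined" (no result reported) in this assay

Compound 2 has no number in this assay, so it cannot be placed on the numbers shown; the only measured point is compound 1, whose value in this assay is 33600 nM. Compound 3, `CO[C@]1(C)O[C@H]2[C@@H](OC/C=C/c3ccccc3)C=C(COC(C)=O)C(=O)[C@@H]2O[C@@]1(C)OC`, differs from compound 2 by 2-phenylethenyl in place of hydrogen on a saturated chain carbon bound to an oxygen on a saturated carbon. Among the measured compounds shown here, no measured step from compound 2 to compound 3 exists, so the size and direction of the change cannot be read from the data, and the expectation rests on compound 1 alone: a weak inhibitor in the same region. Compound 3 is expected to give 30000 nM in this assay, estimated between 8000 nM and 120000 nM.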

Compound 3, half-maximal inhibitory concentration: 44500 nM
Compound 3: middle estimate off by 1.5-fold (0.17 log units), on the low side, and the stated range covers the measured number.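

Measured in this assay, putting 2-phenylethenyl in place of nonyl on a saturated chain carbon bound to an oxygen gives a 1.3-fold higher number from compound 1 to compound 3 (0.12 log units; within the scatter) and so stays within the scatter. At this position, a chain carrying an aromatic ring and a saturated chain of similar reach therefore read alike, and both compounds remain weak inhibitors. No measured evidence offers a reason for this match.

On these data alone, compound 2 has no number, so the steps to it cannot be read, and the effect of adding any such chain to the methoxy compound stays unknown. As far as these compounds go, whether an amine or a carboxylic acid on this chain would shift the number also remains open.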